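Fluoro in Place of Hydrogen, Repeated on a Second Core

The source may hold more compounds than are shown below. What is called first, only, known or untested is meant among the compounds shown, and "the series" means these compounds.

Compound 1, `N/C(=N\NC(=S)N1CCCCCC1)c1ccccn1`, gives 25.3% in a functional assay on MCF7 cells (Homo sapiens) for cytotoxicity, read by MTT assay, with a stated time of 72 h, tested at 1 uM; on this read-out higher numbers stand for more inhibition of growth at the one concentration tested and lower numbers for less inhibition of growth.
Compound 2, `N/C(=N\NC(=S)N1CCSCC1)c1ccccn1`, gives 16.3% in this assay.
Compound 3, `N/C(=N\NC(=S)N1CCSCC1)c1ccc(F)cn1`, gives 30.6% in this assay.

Among the measured compounds shown here, only one step between these compounds can be counted. Compound 3 differs from compound 2 by fluoro in place of hydrogen on an aromatic carbon, and this gave a number 14.3 percentage points higher from compound 2 to compound 3 (beyond the scatter). The difference between the core of compound 1 and the core of compound 2 is not broken down here; their two values lie within the scatter of each other, so nothing is said about order between them. Compound 1 and compound 3 likewise sit within the scatter of each other.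

Compound 4, `N/C(=N\NC(=S)N1CCCCCC1)c1ccc(F)cn1`, has not yet been measured. For the measured compounds named here, it differs from compound 1 by fluoro in place of hydrogen on an aromatic carbon, which is the same change as the one from compound 2 to compound 3, at the same place. Because that step gave a number 14.3 percentage points higher from compound 2 to compound 3 (beyond the scatter), a step of similar size is expected from compound 1 to compound 4 in this assay, namely a number 12.7 percentage points higher from compound 1 to compound 4 (beyond the scatter). Compound 4 is therefore estimated at 38%, expected to fall between 22% and 54%.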

Compound 4, percent growth inhibition at one concentration: 16.8%
Beside the measured number, compound 4's estimate is 21.2 percentage points above it, and the stated range ends above it.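

Put on the other core, fluoro in place of hydrogen gave a number 8.5 percentage points lower from compound 1 to compound 4 (within the scatter) in this assay, so the two values on that core cannot be told apart. The same change at the same place therefore did not repeat from one core to the other: the same change on two cores in this assay, a number 14.3 percentage points higher (beyond the scatter) from compound 2 to compound 3 and a number 8.5 percentage points lower (within the scatter) from compound 1 to compound 4, 22.8 percentage points apart, beyond the scatter of two such steps. A rise seen on one core in this series thus cannot simply be assumed on the other, yet one pair per core does not show why the two results differ, nor what the change would do on any further core.

The compounds shown leave open whether a different group at this place, such as chloro, methyl or methoxy, would also give results that differ between the two cores. They also leave open whether the split between the cores seen with fluoro would persist at other concentrations, since each compound appears here at only one.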